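The source may hold more compounds than are shown below. What is called first, only, known or untested is meant among the compounds shown, and "the series" means these compounds.

Three oxime ethers sharing a piperazine-linked core have been run in a functional assay on HEK293 cells with D(4) dopamine receptor (Homo sapiens) as the target, read by FLIPR; a higher number here means a larger maximal response, a lower number a smaller maximal response. Compound 1 `O/N=C(\CCN1CCN(c2ccccn2)CC1)c1ccccc1Cl` gives 74% in this assay, the highest of the three. Compound 2 `CCO/N=C(\CCN1CCN(c2cccc(OC)c2)CC1)c1ccccc1` gives 30% in this assay, the lowest. Compound 3 `CO/N=C(\CCN1CCN(c2ccccc2OC(C)C)CC1)c1ccc(F)cc1` gives 46% in this assay and so stands second highest of the three; its nearest neighbour on the numbers is compound 2, a value lower by a margin beyond the scatter, and its furthest is compound 1, a value higher by a margin that is also beyond the scatter. Among the compounds with values here, none of these three pairs differs in a single place, so no step between measured compounds can be read off.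

Compound 4 `CO/N=C(/CCN1CCN(c2ccccc2OC(C)C)CC1)c1ccc(F)cc1` is the next entry and has not yet been measured. How it differs from compound 3: the two compounds have the same atoms and bonds and differ only in configuration as drawn: 1 of 1 stereo elements differ; a double bond is drawn E in compound 3 and Z in compound 4

Within the data shown here, no pair in the set so far shows what a change of drawn double-bond geometry does to the maximal response, so the direction of the step is open. A moderate change is expected, more likely downward than upward; the expected step from compound 3 to compound 4 is a number 6 percentage points lower from compound 3 to compound 4 (within the scatter). Compound 4 is estimated to give 40% in this assay, within a range from 20% to 65%.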

Compound 4, largest response reached (reported as efficacy), in percent of the reference or control that the assay uses: 59%
The estimate for compound 4 lay 19 percentage points below the measured number; low and high end bracket the measured number.
By their numbers in this assay, from the lowest: compound 2; then compound 3; then compound 4; then compound 1.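

Notes on the E/Z pair: in this assay, the only change is the drawn geometry of the oxime ether double bond, from E to Z, and it gives a number 13 percentage points higher from compound 3 to compound 4 (beyond the scatter). Within the data shown here, this is the only pair so far that differs in one place, and it shows that the drawn geometry alone can move the maximal response by more than the scatter, with the Z form the higher of the two here. The step can be assigned to that double bond because nothing else separates the two structures: the fact that compounds 3 and 4 differ only in the configuration as drawn.

As far as these compounds go, with a single pair in hand, it remains open whether the Z form also stands higher with the other oxime substitution and aryl groups seen in compound 1 and compound 2. From the compounds shown here alone, it is equally open whether the step keeps its direction and size when a benzyl group sits on the oxime oxygen in place of the methyl group shared by this pair.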